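The source may report more compounds than this note shows. Statements on the series, on what has been measured and on what is new or still open speak of the compounds shown alone.

Compound 1 `CN1C(=O)N(C)C2C1NC(=S)N2/N=C/C=C/c1ccccc1` and compound 2 `CN1C(=O)N(C)C2C1NC(=S)N2/N=C/C=C/c1ccccc1[N+](=O)[O-]` share a core and differ in one place: nitro in place of hydrogen on an aromatic carbon In a functional assay on A549 cells (Homo sapiens) for inhibition, read by MTT assay, with a stated time of 72 h (a lower number here means a stronger inhibitor, a higher number a weaker inhibitor), compound 1 gives 45700 nM, while compound 2 gives 2720 nM, so that a 17-fold lower number from compound 1 to compound 2 (1.23 log units; beyond the scatter). Compound 3 `CCN1C(=O)N(CC)C2C1NC(=S)N2/N=C/C=C/c1ccccc1` carries a different core; the difference between the two cores is not broken down here. In this assay compound 3 gives 6530 nM, which places it between the two others. Compound 4 `CCN1C(=O)N(CC)C2C1NC(=S)N2/N=C/C=C/c1ccccc1[N+](=O)[O-]` is not yet measured and stands to compound 3 as compound 2 stands to compound 1: nitro in place of hydrogen on an aromatic carbon Since the place of the change is described in the same words for both pairs, this is the same change made on a second core. The step from compound 3 to compound 4 is expected to point the same way as the one measured, because a 17-fold lower number from compound 1 to compound 2 (1.23 log units; beyond the scatter) was large, though its size may not carry over unchanged onto the other core, so a somewhat smaller step, a 9.3-fold lower number from compound 3 to compound 4 (0.97 log units; beyond the scatter), is estimated. On that basis compound 4 is expected to give about 700 nM in this assay, most likely between 200 nM and 2500 nM.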

Compound 4, half-maximal inhibitory concentration: > 100000 nM
Compound 4 was reported as a limit; the forecaster's own chance of this, stated with the estimate: 0%; middle value at least 140-fold (2.15 log units) away from the limit.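

In this assay, the change from phenyl to 2-nitrophenyl did not carry over from one core to the other: it gives an at least 15-fold higher number from compound 3 to compound 4 (1.18 log units; beyond the scatter), whereas on the core of compound 1 it gives a 17-fold lower number from compound 1 to compound 2 (1.23 log units; beyond the scatter). The value of compound 4, > 100000 nM, is a limit and not a number. This shows that, for these two cores, the direction of the step depends on the core, but it does not show what in the cores causes this or how the change would behave on any further core: the same change on two cores in this assay, a 17-fold lower number (1.23 log units; beyond the scatter) from compound 1 to compound 2 and an at least 15-fold higher number (1.18 log units; beyond the scatter) from compound 3 to compound 4, at least 250-fold (2.41 log units) apart, beyond the scatter of two such steps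

The compounds shown leave open whether a longer chain, at the place where the core of compound 3 differs from that of compound 1, would follow the pattern of compound 2 or that of compound 4. They also leave open whether an amine or a methoxy group, in place of the nitro group, would split the two cores in the same way.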